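Adding a pyridin-2-yl group to compound 2

The source may report more compounds than this note shows. Statements on the series, on what has been measured and on what is new or still open speak of the compounds shown alone.

In an ADME assay on BaF3 cells (Mus musculus) for cytotoxicity (on this read-out higher numbers stand for an effect only at larger amounts of compound and lower numbers for an effect already at smaller amounts), compound 2 (`CCN1CCN(Cc2ccc(NC(=O)c3cccc(-c4ccc5nc(N)sc5n4)c3)cc2C(F)(F)F)CC1`) gives > 10000 nM, which is a limit of the assay and not a number. Compound 1 (`Nc1nc2ccc(-c3cccc(C(=O)Nc4cccc(C(F)(F)F)c4)c3)nc2s1`) gives > 10000 nM, and this too is a limit. Going by the values given here, the series so far therefore offers only (the limit of > 10000 nM in this assay, at which 2 of the 2 values shown sit). Among the compounds with values here, the one measured step is a step that the two limits leave unreadable from compound 1 to compound 2, with (4-ethylpiperazin-1-yl)methyl in place of hydrogen on an aromatic carbon, and it provides no size to carry forward.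

Compound 3 (`CCN1CCN(Cc2ccc(NC(=O)c3cccc(-c4ccc5nc(Nc6ccccn6)sc5n4)c3)cc2C(F)(F)F)CC1`) departs from compound 2 at a single place: pyridin-2-yl in place of hydrogen on a nitrogen on an aromatic ring. In other words, amino becomes (pyridin-2-yl)amino. Within the data shown here, no measured step involves this nitrogen, so the expectation rests on compound 2 at > 10000 nM and on no step of known size. The expected change is an at least 1.6-fold lower number from compound 2 to compound 3 (0.22 log units; that floor lies within the scatter), a modest estimated shift in this assay toward an effect at smaller amounts, and a reading again at the limit remains about as likely. For compound 3 the estimate is 6000 nM, with an expected range from 1500 nM to 10000 nM.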

Compound 3, half-maximal effective concentration: 3530 nM
Compound 3: the middle estimate sits 1.7-fold (0.23 log units) above what was measured; the measured number falls inside the stated range.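

In this assay, the nitrogen of the amino group turns out to be a place where a change registers: pyridin-2-yl in place of hydrogen there gives an at least 2.8-fold lower number from compound 2 to compound 3 (0.45 log units; beyond the scatter), beyond the scatter and the only step shown whose size can be read, if only as a floor. The earlier step, with (4-ethylpiperazin-1-yl)methyl on an aromatic carbon, cannot be read, so compound 3 is the only compound shown with a number and not a limit, and it gives the series a first reference point for an effect at smaller amounts of compound. Even so, the true size of the step stays unknown, and the other values give no second number to set beside it: the limit of > 10000 nM in this assay, at which 2 of the 3 values shown sit.

The compounds shown leave open whether this shift belongs to pyridin-2-yl itself or would also follow from another group on the same nitrogen, such as phenyl, pyridin-3-yl or acetyl. They also leave open whether pyridin-2-yl would move the reading in the same way on the core of compound 1, without the (4-ethylpiperazin-1-yl)methyl group.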